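Replacing a phenyl with an ethoxy group on the cyclobutane chain

The source may hold more compounds than are shown below. What is called first, only, known or untested is meant among the compounds shown, and "the series" means these compounds.

Of the compounds shown here, three sharing one core have been tested in an assay on isolated protein for agonist activity at prostaglandin E2 receptor EP3 subtype (Homo sapiens); a higher number here means that more compound is needed for the effect, a lower number that less compound is needed. Compound 1 `CCCCC1([C@H](O)/C=C/[C@H]2COC(=O)N2CCSc2nc(C(=O)O)cs2)CCC1` gives 3.9 nM, compound 2 `O=C(O)c1csc(SCCN2C(=O)OC[C@@H]2/C=C/[C@@H](O)C2(CCCCF)CCC2)n1` gives 10 nM, and compound 3 `O=C(O)c1csc(SCCN2C(=O)OC[C@@H]2/C=C/[C@@H](O)C2(CCc3ccccc3)CCC2)n1` gives 27 nM, the highest number of the three; its nearest neighbour is compound 2, and the gap between them is a 2.7-fold higher number from compound 2 to compound 3 (0.43 log units; beyond the scatter). The step from the butyl chain of compound 1 to the phenyl-bearing chain of compound 3 was a 6.9-fold higher number from compound 1 to compound 3 (0.84 log units; beyond the scatter).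

Compound 4 `CCOCCC1([C@H](O)/C=C/[C@H]2COC(=O)N2CCSc2nc(C(=O)O)cs2)CCC1` differs from compound 3 by ethoxy in place of phenyl on a saturated chain carbon, two bonds along the chain from a saturated ring carbon. Both measured steps that end at compound 3 bear on this change, since each exchanges the phenyl for a short saturated chain: a 6.9-fold higher number from compound 1 to compound 3 (0.84 log units; beyond the scatter) and a 2.7-fold higher number from compound 2 to compound 3 (0.43 log units; beyond the scatter). Removing the phenyl again, this time for an ethoxy group of similar reach to the chains of compound 1 and compound 2, is therefore expected to lower the number in this assay by a modest step, estimated as a 3.9-fold lower number from compound 3 to compound 4 (0.59 log units; beyond the scatter). Compound 4 is expected to give about 7 nM, within a range of 2.5 nM to 25 nM.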

Compound 4, half-maximal effective concentration: 2610 nM
Compound 4: the middle estimate sits 370-fold (2.57 log units) below what was measured; measured number outside the range, above it.
By their numbers in this assay, from the lowest: compound 1; then compound 2; then compound 3; then compound 4.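

In this assay, ethoxy in place of phenyl on a saturated chain carbon, two bonds along the chain from a saturated ring carbon, brings a large loss (a 97-fold higher number from compound 3 to compound 4 (1.99 log units; beyond the scatter)), so the phenyl of compound 3 is far better accepted here than its place among the first three compounds suggested. The same ethoxy also stands well apart from the ethyl of compound 1 (a 670-fold higher number from compound 1 to compound 4 (2.83 log units; beyond the scatter)) and the 2-fluoroethyl of compound 2 (a 260-fold higher number from compound 2 to compound 4 (2.42 log units; beyond the scatter)), large steps where all those among the first three compounds were modest, and compound 4 alone carries a hydrogen-bond acceptor in this chain. Nothing given here accounts for the loss.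

As far as these compounds go, what stays open is whether the loss follows the oxygen itself or its place in the chain. A methoxy, a longer ether chain, a hydroxyl or an amine at this place could tell these apart.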